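Cytotoxicity of compound 3 and its cyclohexyl counterpart

The compounds below may be only part of what the source reports. "The series", "measured", "known", "first", "only" and "open" are said of these compounds alone.

- compound 1 `Clc1ccc(Nc2nccs2)cc1OCc1ccoc1`: 26000 nM
- compound 2 `Clc1ccc(Nc2nccs2)cc1OCc1cccs1`: 38000 nM
- compound 3 `CC1=C(COc2cc(Nc3nccs3)ccc2Cl)CCC1`: 11000 nM

In a functional assay on MT2 cells (Homo sapiens) for cytotoxicity, read by MTT assay (on this read-out higher numbers stand for lower toxicity in this test and lower numbers for higher toxicity in this test), compound 3 gives 11000 nM as the lowest of the three numbers, and its steps to both others lie beyond the scatter. Compound 4 `Clc1ccc(Nc2nccs2)cc1OCC1CCCCC1` has not been measured yet. The change reads cyclohexyl in place of 2-methylcyclopent-1-en-1-yl on a saturated chain carbon bound to an oxygen on an aromatic ring and puts cyclohexyl in place of 2-methylcyclopent-1-en-1-yl. Going by the values given here, two measured steps bear on it: a 2.4-fold lower number from compound 1 to compound 3 (0.37 log units; beyond the scatter) and a 3.5-fold lower number from compound 2 to compound 3 (0.54 log units; beyond the scatter) are both modest and lead to the group that now leaves. Neither exchanges one carbon-only ring for another, so no step beyond the scatter is expected. The expected step is a 1.3-fold higher number from compound 3 to compound 4 (0.10 log units; within the scatter) and it stays small. In this assay compound 4 is estimated at 14000 nM with 6000 nM as lower and 32000 nM as upper end.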

Compound 4, half-maximal cytotoxic concentration: 15000 nM
For compound 4 the middle estimate is 1.1-fold (0.03 log units) below the measured one; measured number inside the range.
By their numbers in this assay, from the lowest: compounds 3, 4, 1 and 2 (each within the scatter of the next, the first and the last beyond it).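

In this assay, exchanging one carbon-only ring for another at this place gives a 1.4-fold higher number from compound 3 to compound 4 (0.13 log units; within the scatter) and so leaves the number within the scatter, even with a six-membered ring and no double bond entering. Against the aromatic rings the picture is split: thiophen-2-yl to cyclohexyl gives a 2.5-fold lower number from compound 2 to compound 4 (0.40 log units; beyond the scatter) while furan-3-yl to cyclohexyl gives a 1.7-fold lower number from compound 1 to compound 4 (0.24 log units; within the scatter) and only the first clears the scatter. Nothing measured here accounts for these steps. Still open, going by these compounds, is how a cyclohexyl ring bearing an amine or a carboxylic acid would read, and how an open longer chain would compare.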